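The compounds below may be only part of what the source reports. "The series", "measured", "known", "first", "only" and "open" are said of these compounds alone.

Compound 1 `COc1ccc(-n2ccc(=O)c(C(=O)Nc3ccc(Oc4ccnc5[nH]ccc45)c(F)c3)n2)cc1` gives 46400 nM in a functional assay on PC-3 cells (Homo sapiens) for cytotoxicity, read by MTT assay, with a stated time of 72 h; on this read-out higher numbers stand for weaker inhibition and lower numbers for stronger inhibition.
Compound 2 `COc1ccc(-n2ccc(=O)c(C(=O)Nc3ccc(Oc4ccnc5c4ccn5C)cc3)n2)cc1` reaches only the assay limit, reported as > 60000 nM.
Compound 3 `Cn1ccc2c(Oc3ccc(NC(=O)c4nn(-c5ccc(Cl)cc5)ccc4=O)cc3F)ccnc21` likewise reaches only the assay limit, reported as > 60000 nM.

Compound 3 therefore stands at the upper edge of what this assay reports, and it shares that position with one other compound, as the limit of > 60000 nM in this assay, at which 2 of the 3 values shown sit, records. For the measured compounds named here, no two measured compounds differ from each other in a single place, so no measured step is available, and the three values give no direction for any single change.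

The next compound, compound 4 `COc1ccc(-n2ccc(=O)c(C(=O)Nc3ccc(Oc4ccnc5c4ccn5C)c(F)c3)n2)cc1`, differs from compound 3 in one place: methoxy in place of chloro on an aromatic carbon. Compound 4 thus carries the methoxyphenyl group that compound 1 also bears, together with the methylated core of compound 2 and compound 3.

With compound 3 at the limit and compound 2 at the limit as well, no step beyond the scatter is expected in this assay; the likely outcome is a further limit, or a number near it, as compound 1 shows for a related substitution pattern. Compound 4 is expected to give about 65000 nM in this assay, within a range from 30000 nM to 200000 nM, the expected step being a step that the limit leaves unreadable from compound 3 to compound 4.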

Compound 4, half-maximal inhibitory concentration: > 60000 nM
Compound 4: only a limit was reported; the forecaster's own chance of this, stated with the estimate: 60%; the middle value does not contradict the limit.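

Compound 4 gives a limit, not a number, in this assay: the limit of > 60000 nM in this assay, at which 3 of the 4 values shown sit.

The steps from compound 3 and from compound 2 to compound 4 cannot be read, so neither methoxy in place of chloro para to a large group nor fluoro in place of hydrogen on an aromatic carbon has a measurable size here. For the compounds shown here, the only readable step is an at least 1.2-fold higher number from compound 1 to compound 4 (0.11 log units; that floor lies within the scatter), with methyl in place of hydrogen on an aromatic nitrogen; this establishes no change beyond the scatter, though it does not rule one out.

With most values at the limit, the effect of the group on the aromatic carbon para to a large group remains unresolved, including whether an amine or a carboxylic acid there would give a number rather than a limit. Also open, going by these compounds, is whether the hydrogen on the aromatic nitrogen matters, since only compound 1 carries it and the comparison rests on a single pair.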